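A Fluorine for Chlorine Swap on a Non-Toxic Core

The source may report more compounds than this note shows. Statements on the series, on what has been measured and on what is new or still open speak of the compounds shown alone.

The series shares the core seen in compound 1 `CS(=O)(=O)CCCn1c(Cn2c(=O)n(C3CC3)c3ccncc32)cc2cc(Cl)ccc21`. In an ADME assay on HeLa cells (Homo sapiens) for cytotoxicity, read by ATP content, with a stated time of 3 days (on this read-out higher numbers stand for lower toxicity in this test and lower numbers for higher toxicity in this test), compound 1 gives > 50000 nM, which is a limit of the assay rather than a number. Compound 2 `O=C(O)CCCn1c(Cn2c(=O)n(C3CC3)c3ccncc32)cc2cc(Cl)ccc21`, carrying carboxy in place of methylsulfonyl on a saturated chain carbon, three bonds along the chain from an aromatic nitrogen, stands at > 50000 nM in this assay, again a limit. Compound 3 `CC1(n2c(=O)n(Cc3cc4cc(Cl)ccc4n3CCCS(C)(=O)=O)c3cnccc32)CC1`, with methyl in place of hydrogen on a saturated ring carbon, gives > 50000 nM, once more a limit. Accordingly the step that the two limits leave unreadable from compound 1 to compound 2 and the step that the two limits leave unreadable from compound 1 to compound 3 cannot be sized; all that is known is the limit of > 50000 nM in this assay, at which 3 of the 3 values shown sit.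

Compound 4 `CS(=O)(=O)CCCn1c(Cn2c(=O)n(C3CC3)c3ccncc32)cc2cc(F)ccc21` differs from compound 1 by fluoro in place of chloro on an aromatic carbon. Neither measured step touches this aromatic carbon, and neither can be read, so no direction can be drawn from them; the whole set simply sits at the limit. Compound 4 is therefore expected to stay at the limit as well, with an estimated step that the limit leaves unreadable from compound 1 to compound 4. The estimated value of compound 4 is 70000 nM, in a range from 30000 nM to 200000 nM.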

Compound 4, half-maximal cytotoxic concentration: > 50000 nM
Compound 4: no number, only a limit (the forecaster's own chance of this, stated with the estimate: 80%); the middle value lies beyond the limit too.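

Compound 4, like compound 1, stands at a limit of the assay and not at a number, so no step between them can be read: the limit of > 50000 nM in this assay, at which 4 of the 4 values shown sit.

The compounds shown leave open how far each lies beyond that limit, and which change to the shared core, if any, would give a readable value in this assay.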